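A Bromine Substituent on the Core of Compound 1

The source may report more compounds than this note shows. Statements on the series, on what has been measured and on what is new or still open speak of the compounds shown alone.

Measured in an assay on K177 cells with Neuronal acetylcholine receptor; alpha4/beta2 (Homo sapiens) as the target; on this read-out higher numbers stand for larger maximal responses and lower numbers for smaller maximal responses:
compound 1 `CN1CCC[C@H]1COc1cccnc1` gives 100%
compound 2 `Cc1ccncc1OC[C@@H]1CCCN1C` gives 73.9%
compound 3 `Cc1cncc(OC[C@@H]2CCCN2C)c1` gives 77%

Compound 1 stands highest of the three, and both other compounds lie beyond the scatter below it. Compound 4 `CN1CCC[C@H]1COc1ccc(Br)nc1` differs from compound 1 in one place: bromo in place of hydrogen on an aromatic carbon, placed next to the ring nitrogen and para to the group of 8 heavy atoms. The two measured steps, each adding a substituent to the shared core, were a number 26.1 percentage points lower from compound 1 to compound 2 (beyond the scatter) and a number 23 percentage points lower from compound 1 to compound 3 (beyond the scatter). Bromo at a fresh position is a different change, so a smaller drop, or none beyond the scatter, remains plausible. A modest fall of a number 20 percentage points lower from compound 1 to compound 4 (beyond the scatter) is therefore expected. Compound 4 is estimated at 80%, between 55% and 105%.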

Compound 4, largest response reached (reported as maximum), in percent of the reference or control that the assay uses: 42.5%
Estimate against measurement, compound 4: 37.5 percentage points above, outside the stated range (below it).
By their numbers in this assay, from the lowest: compound 4; then compounds 2 and 3 (each within the scatter of the next); then compound 1.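

In this assay, bromo in place of hydrogen on this aromatic carbon, next to the ring nitrogen, gives a number 57.5 percentage points lower from compound 1 to compound 4 (beyond the scatter). This single added atom therefore brings a large step, where the two methyl steps at other positions were modest. No measurement shown here accounts for the size of this drop.

On these data alone, whether the loss belongs to bromo itself or to this position remains open. Fluoro, methyl or an amine on the same carbon would help to separate the two.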